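The compounds below may be only part of what the source reports. "The series", "measured", "known", "first", "only" and "open" are said of these compounds alone.

Compounds measured so far in a functional assay on MCF7 cells (Homo sapiens) for inhibition, read by radiometric assay and XTT assay; a lower number here means a stronger inhibitor, a higher number a weaker inhibitor:

Compound 1 `C=CCC1=C(O)S[C@](C)(CCCCCCCC)C1=O` gives 44.4 ug/mL
Compound 2 `CCCCCC[C@@]1(C)SC(=O)C=C1OC` gives 9.4 ug/mL
Compound 3 `CCCCCCCC[C@@]1(C)SC(=O)C=C1OC` gives 16.4 ug/mL

Compound 2 stands at the low end of these numbers. Compound 2 and compound 3 lie within the scatter of each other, and the value of compound 1 is clearly higher than that of compound 2.

The unmeasured compound 4 `CCCCCC[C@@]1(C)SC(=O)C=C1OCC(=O)OCC` departs from compound 2 by one change, (ethoxycarbonyl in place of hydrogen on a saturated chain carbon bound to an oxygen on an unsaturated carbon), which is ethoxycarbonyl in place of hydrogen on a saturated chain carbon bound to an oxygen on an unsaturated carbon. Cut one bond further out, it reads methyl to (ethoxycarbonyl)methyl.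

Within the data shown here, only one measured step bears on this, and only indirectly. It is a 1.7-fold higher number from compound 2 to compound 3 (0.24 log units; within the scatter), a small step made at another place in the molecule, on the chain. Among the measured compounds shown here, no measured step touches the place of the new change, so the evidence is thin. In this assay a slightly higher number is expected, with no step beyond the scatter. The estimate means a 1.5-fold higher number from compound 2 to compound 4 (0.17 log units; within the scatter) as the expected step. For compound 4 the estimated value is 14 ug/mL, with an expected range from 5 ug/mL to 40 ug/mL.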

Compound 4, half-maximal inhibitory concentration: 39.6 ug/mL
For compound 4 the middle estimate is 2.8-fold (0.45 log units) below the measured one, within the range that was stated.
By their numbers in this assay, from the lowest: compounds 2 and 3 (each within the scatter of the next); then compounds 4 and 1 (each within the scatter of the next).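

In this assay, the place on a saturated chain carbon bound to an oxygen on an unsaturated carbon proves sensitive to substitution: adding ethoxycarbonyl there gives a 4.2-fold higher number from compound 2 to compound 4 (0.62 log units; beyond the scatter) and so makes compound 4 the weaker inhibitor of the pair. Among these compounds, the only earlier single-place step, on the chain, was a 1.7-fold higher number from compound 2 to compound 3 (0.24 log units; within the scatter) and stayed within the scatter, so it gave no sign that a single change to compound 2 could move the number beyond the scatter. Nothing among the data shown accounts for the rise at this place, so it stands as an observation without an explanation.

With a single substituent at this place, the compounds shown leave open whether the rise follows from the whole ethoxycarbonyl group or from one part of it, and a carboxylic acid or an amide on the same carbon would help separate those readings. They also leave open whether ethoxycarbonyl on that carbon would give a similar step when combined with the longer chain of compound 3.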